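A few compounds are considered here, and "the series" means these few. Any claim that something is new, unique, unknown or untested is made for them only; others in the source may bear on it.

Measured compounds:
compound 1 `Cc1cccc(/C(N)=N/NC(=S)N2CCSCC2)n1` gives 62.6%;
compound 2 `Cc1cccc(/C(N)=N/NC(=S)N2CCOCC2)n1` gives 43.6%;
compound 3 `N/C(=N\NC(=S)N1CCSCC1)c1ccc(F)cn1` gives 70.9%, all in a functional assay on A-375 cells (Homo sapiens) for cytotoxicity, read by MTT assay, with a stated time of 72 h, tested at 10 uM; a lower number here means less inhibition of growth, a higher number more inhibition of growth at the concentration tested.

Compound 1 and compound 2 differ by one change, (morpholin-4-yl in place of thiomorpholin-4-yl on a thiocarbonyl carbon), and that change made the step of a number 19 percentage points lower from compound 1 to compound 2 (beyond the scatter). Compound 3 carries a different core, and the difference between the two cores is not broken down here; in this assay compound 3 and compound 1 lie within the scatter of each other, while compound 2 sits lower than both. Compound 4 `N/C(=N\NC(=S)N1CCOCC1)c1ccc(F)cn1`, not yet measured, arises from compound 3 by the same change, (morpholin-4-yl in place of thiomorpholin-4-yl on a thiocarbonyl carbon), made on the same kind of place. Because the earlier step of a number 19 percentage points lower from compound 1 to compound 2 (beyond the scatter) was a drop of modest size, a similar step is expected here, a number 18.9 percentage points lower from compound 3 to compound 4 (beyond the scatter). Compound 4 is therefore estimated at 52%, with a range from 38% to 65%.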

Compound 4, percent growth inhibition at one concentration: 70.3%
Compound 4: the middle estimate sits 18.3 percentage points below what was measured, outside the stated range (above it).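

In this assay, morpholin-4-yl in place of thiomorpholin-4-yl on a thiocarbonyl carbon gave a number 0.6 percentage points lower from compound 3 to compound 4 (within the scatter), so the change did not carry over at the same size from one core to the other: the same change on two cores in this assay, a number 19 percentage points lower (beyond the scatter) from compound 1 to compound 2 and a number 0.6 percentage points lower (within the scatter) from compound 3 to compound 4, 18.4 percentage points apart, beyond the scatter of two such steps Within these two pairs, the effect of the change therefore cannot be assumed to transfer between cores. The two pairs give no rule for any further core, and they do not show which feature of the cores goes with the difference.

The compounds shown leave open how the step would look with piperidin-1-yl on the thiocarbonyl carbon. They also leave open what it would be on a core carrying chlorine in place of the fluorine of compound 4.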